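This account rests on a few compounds, and the source may have more. Where it says the series, first, only, none or still open, it means among the compounds named here.

Of the compounds shown here, three sharing one core have been measured so far in a functional assay on PC-3 cells (Homo sapiens) for cytotoxicity, read by MTT assay, with a stated time of 48 h (on this read-out lower numbers stand for stronger inhibition and higher numbers for weaker inhibition), on this read-out. Compound 1 (`COc1cc(-n2c(-c3ccc([N+](=O)[O-])cc3)cn(C(C)=O)c2=O)cc(OC)c1OC`) gives 32900 nM with its 4-nitrophenyl group, compound 2 (`COc1ccc(-c2cn(C(C)=O)c(=O)n2-c2cc(OC)c(OC)c(OC)c2)cc1`) gives 19700 nM with its 4-methoxyphenyl group, and compound 3 (`COc1cc(-n2c(-c3ccc(F)cc3F)cn(C(C)=O)c2=O)cc(OC)c1OC`) gives 34300 nM with its 2,4-difluorophenyl group. Compound 2 thus stands within the scatter of both other compounds, and the three cannot be ranked.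

Compound 4 (`COc1ccc(-c2cn(C(C)=O)c(=O)n2-c2cc(OC)c(OC)c(OC)c2)cc1[N+](=O)[O-]`) keeps all of compound 2 and differs from it in one place (nitro in place of hydrogen on an aromatic carbon): a nitro in place of hydrogen on an aromatic carbon, ortho to a methoxy group and meta to a large group. The closest evidence is a 1.7-fold lower number from compound 1 to compound 2 (0.22 log units; within the scatter) with methoxy in place of nitro. Exchanging the whole aromatic group gave a 1.7-fold higher number from compound 2 to compound 3 (0.24 log units; within the scatter) and also a 1.0-fold higher number from compound 1 to compound 3 (0.02 log units; within the scatter) in the same series. All of these steps lie within the scatter. Among the measured compounds shown here, no measured compound carries nitro and methoxy together, so the guidance is indirect.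

No step beyond the scatter is therefore expected in this assay here. The estimated change is a 1.3-fold higher number from compound 2 to compound 4 (0.10 log units; within the scatter) and it is expected to stay small, with no firm direction. For compound 4 the estimated value is 25000 nM with an expected range from 11000 nM to 55000 nM when it is measured.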

Compound 4, half-maximal inhibitory concentration: 30300 nM
For compound 4 the middle estimate is 1.2-fold (0.08 log units) below the measured one, and the stated range covers the measured number.
By their numbers in this assay, from the lowest: compounds 2, 4, 1 and 3 (each within the scatter of the next).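

In this assay the position ortho to a methoxy group and meta to a large group accepts a nitro in place of hydrogen, with a 1.5-fold higher number from compound 2 to compound 4 (0.19 log units; within the scatter) and thus no step beyond the scatter. Compound 4 is the first compound shown that carries nitro and methoxy together on one aromatic ring, and this pairing leaves it within the scatter of compound 2, so the earlier exchanges of the whole aromatic group are now joined by a change of a single hydrogen that also cannot be ranked. Nothing measured on these compounds bears on what lies behind this result.

The compounds shown leave open whether this position stays as undemanding with other groups, such as an amine or a carboxylic acid, since nitro is the only group other than hydrogen seen there. They also leave open whether a longer chain in place of the neighbouring methoxy group, with the nitro kept, would produce a step beyond the scatter in this assay at all.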